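The source may hold more compounds than are shown below. What is called first, only, known or untested is meant among the compounds shown, and "the series" means these compounds.

Compound 1 `C=C[C@@](C)(CC[C@H]1C(C)=CC[C@H]2C(C)(C)CCC[C@]12C)O[C@@H]1O[C@H](C)[C@H](O)[C@H](O)[C@H]1O` — 4.2 ug/mL
Compound 2 `C=C[C@@](C)(CC[C@H]1C(C)=CC[C@H]2C(C)(C)CCC[C@]12C)O[C@@H]1O[C@H](C)[C@H](OC(C)=O)[C@H](O)[C@H]1O` — 8.9 ug/mL

In a functional assay on XF498 cells (Homo sapiens) for cytotoxicity, read by sulforhodamine B assay (a higher number here means that more compound is needed for the effect, a lower number that less compound is needed), compound 1 gives the lowest of the two numbers; its nearest neighbour is compound 2, reached by a 2.1-fold higher number from compound 1 to compound 2 (0.33 log units; beyond the scatter). Compound 3 `C=C[C@@](C)(CC[C@H]1C(C)=CC[C@H]2C(C)(C)CCC[C@]12C)O[C@@H]1O[C@H](C)[C@H](O)[C@H](OC(C)=O)[C@H]1O` differs from compound 1 by acetyl in place of hydrogen on an oxygen on a saturated carbon. Within the data shown here, the only measured step that bears on this is a 2.1-fold higher number from compound 1 to compound 2 (0.33 log units; beyond the scatter), where the same kind of change, hydroxy to acetoxy, gave a modest rise. A similar modest rise is therefore expected here, a 1.8-fold higher number from compound 1 to compound 3 (0.25 log units; within the scatter). Compound 3 is estimated at 7.5 ug/mL, with a likely range from 3.5 ug/mL to 16 ug/mL.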

Compound 3, concentration for half-maximal effect: 5.1 ug/mL
Compound 3: middle estimate off by 1.5-fold (0.17 log units), on the high side; the range from low to high includes it.
By their numbers in this assay, from the lowest: compounds 1, 3 and 2 (each within the scatter of the next, the first and the last beyond it).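

In this assay, acetyl on this oxygen gives a 1.2-fold higher number from compound 1 to compound 3 (0.08 log units; within the scatter), so the hydrogen of this hydroxy can be replaced without a change beyond the scatter. The same change on the other oxygen gave a 2.1-fold higher number from compound 1 to compound 2 (0.33 log units; beyond the scatter), so hydroxy to acetoxy does not give the same result at every oxygen of compound 1. Nothing available explains this contrast between the two oxygens.

As far as these compounds go, whether a longer chain such as butyryl or a larger group such as benzoyl would behave like acetyl on this oxygen remains open. So does the effect of an amine in place of this hydroxy.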